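Swapping one halogenated benzyl group for another

This account rests on a few compounds, and the source may have more. Where it says the series, first, only, none or still open, it means among the compounds named here.

The three measured compounds and their values in an assay on isolated protein for inhibition of Amine oxidase [flavin-containing] A (Homo sapiens), read by fluorescence, with stated times of 15 min and 20 min; on this read-out lower numbers stand for stronger inhibition and higher numbers for weaker inhibition:
compound 1, `Cc1ccccc1CN1CCC(CCNC(=O)/C=C/c2cc(C(C)(C)C)c(O)c(C(C)(C)C)c2)CC1`, gives 69300 nM
compound 2, `CC(C)(C)c1cc(/C=C/C(=O)NCCC2CCN(Cc3ccc(F)cc3F)CC2)cc(C(C)(C)C)c1O`, gives 70600 nM
compound 3, `CC(C)(C)c1cc(/C=C/C(=O)NCCC2CCN(Cc3ccccc3Cl)CC2)cc(C(C)(C)C)c1O`, gives 72100 nM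

Compound 3 carries the highest of the three numbers, yet both steps leading to it, a 1.0-fold higher number from compound 1 to compound 3 (0.02 log units; within the scatter) and a 1.0-fold higher number from compound 2 to compound 3 (0.01 log units; within the scatter), lie within the scatter, so the three compounds cannot be told apart on these data.

Compound 4, `CC(C)(C)c1cc(/C=C/C(=O)NCCC2CCN(Cc3ccc(Br)cc3)CC2)cc(C(C)(C)C)c1O`, differs from compound 3 by 4-bromophenyl in place of 2-chlorophenyl on a saturated chain carbon bound to an amine nitrogen in a ring. Every change made so far at this part of the molecule left the read-out where it was: a 1.0-fold higher number from compound 1 to compound 2 (0.01 log units; within the scatter), a 1.0-fold higher number from compound 1 to compound 3 (0.02 log units; within the scatter) and a 1.0-fold higher number from compound 2 to compound 3 (0.01 log units; within the scatter) were all within the scatter. The change to compound 4 is of the same kind, one halogen-bearing phenyl exchanged for another on the same carbon. In this assay no step beyond the scatter is therefore expected, a 1.0-fold lower number from compound 3 to compound 4 (0.00 log units; within the scatter). Compound 4 is estimated to give 72000 nM, with an expected range from 32000 nM to 160000 nM.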

Compound 4, half-maximal inhibitory concentration: 73200 nM
Compound 4: middle estimate off by 1.0-fold (0.01 log units), on the low side; low and high end bracket the measured number.
By their numbers in this assay, from the lowest: compounds 1, 2, 3 and 4 (each within the scatter of the next).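

In this assay, going from 2-chlorophenyl to 4-bromophenyl changes both the halogen and the number of its ring position in the group's name, yet the result is only a 1.0-fold higher number from compound 3 to compound 4 (0.01 log units; within the scatter) and no real shift. The comparisons with the other two groups read the same way, with a 1.0-fold higher number from compound 2 to compound 4 (0.02 log units; within the scatter) and with a 1.1-fold higher number from compound 1 to compound 4 (0.02 log units; within the scatter) as well, so bromine now joins methyl, chlorine and two fluorines as substituents on this phenyl that cannot be told apart on these data. Nothing available here accounts for this lack of difference.

Going by these compounds, all four compounds keep a substituted phenyl on this carbon, so it stays open what a cyclohexyl in its place, or a phenyl carrying an amine or a carboxylic acid, would do to the read-out. On these data alone, it also stays open whether any change at this position can move the number beyond the scatter.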